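Removing the Hydroxy Group of Compound 1

The source may hold more compounds than are shown below. What is called first, only, known or untested is meant among the compounds shown, and "the series" means these compounds.

Compound 1 `COc1cc(-c2ccccc2)cc(O)c1O` reaches only a limit in a functional assay on SK-MEL-2 cells (Homo sapiens) for cytotoxicity, read by sulforhodamine B assay; on this read-out higher numbers stand for weaker inhibition and lower numbers for stronger inhibition: > 10000 nM.
Compound 2 `COc1cc(-c2ccccc2)cc(OC)c1OC` likewise gives only a limit in this assay: > 10000 nM.
Compound 3 `COc1cc(OC)cc(-c2ccccc2O)c1` also sits at a limit in this assay: > 10000 nM.

Compound 1 therefore stands nowhere above the others: every value shown is a limit, as the limit of > 10000 nM in this assay, at which 3 of the 3 values shown sit, records, so no ordering among the three is possible. Going by the values given here, no step between measured compounds is available to guide the next change. Compound 4 `COc1cc(O)cc(-c2ccccc2)c1` differs from compound 1 by hydrogen in place of hydroxy on an aromatic carbon. Among the compounds with values here, with no measured step to draw on, the expectation for this assay is no shift beyond the scatter, and the step that the limit leaves unreadable from compound 1 to compound 4 is estimated to leave compound 4 at the limit. Compound 4 is thus expected to give about 20000 nM, within 8000 nM to 60000 nM.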

Compound 4, half-maximal inhibitory concentration: > 10000 nM
Compound 4: only a limit was reported; the forecaster's own chance of this, stated with the estimate: 85%; the middle value does not contradict the limit.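

Compound 1 and compound 4 both stay at a limit, so no step between them can be read in this assay: the limit of > 10000 nM in this assay, at which 4 of the 4 values shown sit.

The compounds shown leave open whether any change to the shared core would give a measurable value in this assay.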